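The source may report more compounds than this note shows. Statements on the series, on what has been measured and on what is new or still open speak of the compounds shown alone.

Series notes. Compound 2 `COc1cc(-c2cc(/C=C/C(=O)c3ccc(N)cc3)[nH]n2)cc(OC)c1OC` is the reference point for this step. In a functional assay on MOLT-4 cells (Homo sapiens) for inhibition, read by sulforhodamine B assay, with a stated time of 48 h (on this read-out lower numbers stand for stronger inhibition of growth and higher numbers for weaker inhibition of growth), compound 2 gives 8510 nM, the lowest of the three numbers recorded so far. Compound 1 `COc1ccc(-c2cc(/C=C/C(=O)c3ccc(N)cc3)[nH]n2)cc1`, which shares the enone and aminophenyl ketone but carries a single methoxy group on the pendant aryl, gives in this assay 9480 nM, a number within the scatter of compound 2. Compound 3 `COc1cc(-c2cc(/C=C/C(=O)c3ccc(Cl)c(Cl)c3)[nH]n2)cc(OC)c1OC` gives in this assay 40600 nM. Among the measured compounds shown here, the one measured change at the ketone end of the chain is a 4.8-fold higher number from compound 2 to compound 3 (0.68 log units; beyond the scatter); it is the only step that bears directly on the change now considered.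

Compound 4 `COc1cc(-c2cc(/C=C/C(=O)c3ccc(F)c(F)c3)[nH]n2)cc(OC)c1OC` differs from compound 2 in the same position: 3,4-difluorophenyl in place of 4-aminophenyl on a carbonyl carbon. The measured comparison points in one direction, the loss of the aminophenyl ketone for a dihalogenated aryl ketone weakened growth inhibition. Whether two fluorine atoms reproduce the full size of the chlorine step is not known from these three compounds, so the expected change is set between no change and the dichloro step. Compound 4 is therefore expected to show a 2.9-fold higher number from compound 2 to compound 4 (0.47 log units; beyond the scatter) in this assay. The estimate for compound 4 in this assay is 25000 nM, with a plausible range from 10000 nM to 60000 nM.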

Compound 4, concentration for total growth inhibition: 9090 nM
Compound 4: middle estimate off by 2.8-fold (0.44 log units), on the high side; measured number outside the range, below it.
By their numbers in this assay, from the lowest: compounds 2, 4 and 1 (each within the scatter of the next); then compound 3.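

In this assay, a 1.1-fold higher number from compound 2 to compound 4 (0.03 log units; within the scatter), so on this carbonyl carbon 3,4-difluorophenyl can stand in place of 4-aminophenyl with no change beyond the scatter, even though the entering group has 0 hydrogen-bond donors against 1 in the group that leaves. Within the same position, a 4.5-fold lower number from compound 3 to compound 4 (0.65 log units; beyond the scatter), and with a 4.8-fold higher number from compound 2 to compound 3 (0.68 log units; beyond the scatter) this shows that the weaker growth inhibition belongs to 3,4-dichlorophenyl in this set and does not extend to both dihalogenated aryl ketones, so the identity of the halogen matters here and compound 3 stands apart from compound 2 and compound 4. No measurement at hand accounts for this difference between the two halogenated groups.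

The compounds shown leave open whether other groups on this carbonyl carbon, such as 4-fluorophenyl, 4-hydroxyphenyl or 3,4-dibromophenyl, would track compound 4 or compound 3. Among the compounds shown here, it also remains open whether 3,4-difluorophenyl would behave the same way on the core of compound 1, with its single methoxy group on the pendant aryl.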